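Pyrimidin-2-yl on the sulfonamide nitrogen: compound 3

The source may hold more compounds than are shown below. What is called first, only, known or untested is meant among the compounds shown, and "the series" means these compounds.

- compound 1 `O=S(=O)(Nc1ncccn1)c1ccc2c(c1)OCC[C@@H]2c1ccc(C(F)(F)F)cc1-c1ccc(F)nc1` gives 408000 nM
- compound 2 `Cn1nccc1-c1cc(C(F)(F)F)ccc1[C@H]1CCOc2cc(S(=O)(=O)Nc3cccc(F)n3)ccc21` gives 27000 nM

In a physicochemical assay for solubility (on this read-out higher numbers stand for higher solubility and lower numbers for lower solubility), compound 2 is the lower of the two at 27000 nM and compound 1 stands higher at 408000 nM with a gap beyond the usual scatter. Compound 3 `Cn1nccc1-c1cc(C(F)(F)F)ccc1[C@H]1CCOc2cc(S(=O)(=O)Nc3ncccn3)ccc21` is not yet measured. Its difference from compound 2 is pyrimidin-2-yl in place of 6-fluoropyridin-2-yl on a sulfonamide nitrogen in which pyrimidin-2-yl takes the place of 6-fluoropyridin-2-yl on a sulfonamide nitrogen. For the measured compounds named here, no measured pair isolates this change. Compound 1 also carries pyrimidin-2-yl on a sulfonamide nitrogen and gives 408000 nM in this assay so a rise beyond the scatter is expected, though smaller than the gap between compound 1 and compound 2. The estimated step is a 5.6-fold higher number from compound 2 to compound 3 (0.74 log units; beyond the scatter) and remains an expectation. The expected value for compound 3 is 150000 nM (range from 50000 nM to 400000 nM).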

Compound 3, solubility: 532000 nM
Compound 3: the middle estimate sits 3.5-fold (0.55 log units) below what was measured; the whole stated range lies below it.
By their numbers in this assay, from the lowest: compound 2; then compounds 1 and 3 (each within the scatter of the next).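

In this assay, the sulfonamide nitrogen now has a change that can be read on its own: with 1-methyl-1H-pyrazol-5-yl held on the aromatic carbon, pyrimidin-2-yl in place of 6-fluoropyridin-2-yl gives a 20-fold higher number from compound 2 to compound 3 (1.29 log units; beyond the scatter), a large step. With pyrimidin-2-yl held on the sulfonamide nitrogen, 1-methyl-1H-pyrazol-5-yl in place of 6-fluoropyridin-3-yl on the aromatic carbon gives a 1.3-fold higher number from compound 1 to compound 3 (0.12 log units; within the scatter), so this pair does not separate beyond the scatter. No measurement shown accounts for the large step.

Open, as far as these compounds go, is whether the large step tracks the extra ring nitrogen of pyrimidin-2-yl or the loss of the fluorine of 6-fluoropyridin-2-yl, a question that unsubstituted pyridin-2-yl on the sulfonamide nitrogen would address. Also open, from the compounds shown here alone, is whether the step holds with 6-fluoropyridin-3-yl on the aromatic carbon.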